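The source may hold more compounds than are shown below. What is called first, only, known or untested is meant among the compounds shown, and "the series" means these compounds.

Compounds measured in a functional assay on the whole organism (strain Wistar) for inhibition, with Rattus norvegicus as the target, read by paw edema, with a stated time of 2 h, at a dose of 30 mg/kg; on this read-out higher numbers stand for more inhibition at the one dose given (going by the name of the read-out) and lower numbers for less inhibition:
compound 1 `COc1ccc2sc(NC(=O)CN3CCN(c4ccccc4)CC3)nc2c1` gives 21.7%;
compound 2 `COc1ccc2sc(NC(=O)CN3CCCNCC3)nc2c1` gives 17.4%;
compound 3 `CCN1CCN(CC(=O)Nc2nc3cc(OC)ccc3s2)CC1` gives 17.4%.

Compound 3 stands level with compound 2 at the digits shown, and together they are the lowest of the three numbers; the one measured single-change step is a number 4.3 percentage points lower from compound 1 to compound 3 (within the scatter), which lies within the scatter. Compound 4 `COc1ccc2sc(NC(=O)CN3CCNCC3)nc2c1` has not been measured. It differs from compound 3 by hydrogen in place of ethyl on an amine nitrogen in a ring. Among the measured compounds shown here, the one measured step at the same position, ethyl in place of phenyl, gave a number 4.3 percentage points lower from compound 1 to compound 3 (within the scatter), within the scatter, so a change at this ring nitrogen has so far moved the read-out little. Compound 4 is therefore expected to show a number 0.4 percentage points lower from compound 3 to compound 4 (within the scatter), and its value in this assay is estimated at 17%, between 9% and 26%.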

Compound 4, a percentage reported as inhibition, in the whole organism at one dose (the size of the read-out at that dose, not a potency): 2.17%
Estimate against measurement, compound 4: 14.8 percentage points above; measured number outside the range, below it.
By their numbers in this assay, from the lowest: compound 4; then compounds 2, 3 and 1 (each within the scatter of the next).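

Hydrogen in place of ethyl on the amine nitrogen in the ring gives, in this assay, a number 15.2 percentage points lower from compound 3 to compound 4 (beyond the scatter), and hydrogen in place of phenyl gives a number 19.5 percentage points lower from compound 1 to compound 4 (beyond the scatter), so this position does affect the read-out once its substituent is removed altogether, although exchanging ethyl for phenyl stayed within the scatter. Ring size also counts when that nitrogen carries hydrogen: piperazin-1-yl in place of 1,4-diazepan-1-yl gives a number 15.2 percentage points lower from compound 2 to compound 4 (beyond the scatter). No measurement available here accounts for these drops.

As far as these compounds go, whether methyl or benzyl on this nitrogen would match ethyl and phenyl remains open. So does the effect of an ethyl group on the 1,4-diazepan-1-yl ring.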